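Compound 1 to compound 4: a larger group on nitrogen

The source may hold more compounds than are shown below. What is called first, only, known or untested is meant among the compounds shown, and "the series" means these compounds.

Measured in a functional assay on LNCaP cells (Homo sapiens) for cytotoxicity; on this read-out lower numbers stand for stronger inhibition and higher numbers for weaker inhibition:
- compound 1 `CNC(=O)Nc1ccc(-c2nc(N3CC4CCC(C3)O4)c3cnn(C(C)C)c3n2)cc1`: 5 nM
- compound 2 `CNC(=O)Nc1ccc(-c2nc(N3CC4CCC(C3)O4)c3cnn(C)c3n2)cc1`: 170 nM
- compound 3 `O=C(Nc1ccc(-c2nc(N3CC4CCC(C3)O4)c3cnn(C4CCC5(CC4)OCCO5)c3n2)cc1)Nc1cccnc1`: 1 nM

Not yet measured: compound 4 `CNC(=O)Nc1ccc(-c2nc(N3CC4CCC(C3)O4)c3cnn([C@H]4CC[C@@H](OC)CC4)c3n2)cc1`.

Compound 1 holds the middle place of the three numbers, with compound 3 lower at 1 nM and compound 2 higher at 170 nM. The change under study is 4-methoxycyclohexyl in place of isopropyl on an aromatic nitrogen.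

Among the compounds with values here, one measured step bears directly on this nitrogen: a 34-fold higher number from compound 1 to compound 2 (1.53 log units; beyond the scatter), a large step with methyl in place of isopropyl. It runs toward a smaller group, so it does not settle what a larger one does. Within the data shown here, compound 3 also has a ring in that place and shows 1 nM, but it differs from compound 1 in more than one place and gives no clean step. In this assay, no step beyond the scatter is therefore expected, with a slight lean toward a lower number.

For compound 4 the expected value is 4 nM, with an estimated range of 1 nM to 20 nM. The expected change is a 1.3-fold lower number from compound 1 to compound 4 (0.10 log units; within the scatter).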

Compound 4, half-maximal inhibitory concentration: 1 nM
Compound 4: middle estimate off by 4.0-fold (0.60 log units), on the high side; the range from low to high includes it.
By their numbers in this assay, from the lowest: compounds 3 and 4 (each within the scatter of the next); then compound 1; then compound 2.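

In this assay the step of a 5.0-fold lower number from compound 1 to compound 4 (0.70 log units; beyond the scatter) gives this nitrogen its first clean reading toward a larger group, and it runs the opposite way from the loss seen on going down to methyl. The step of a 170-fold lower number from compound 2 to compound 4 (2.23 log units; beyond the scatter) widens the span, and across compound 2, compound 1 and compound 4, which differ only in this group, the number falls from methyl through isopropyl to 4-methoxycyclohexyl. No measurement at hand accounts for the gain.

Open, on these data alone, is how much of the step belongs to the six-membered ring and how much to its methoxy, which a plain cyclohexyl or a 4-aminocyclohexyl on this nitrogen would help to separate. Also open, as far as these compounds go, is whether the opposite arrangement at the two defined stereocentres gives a similar number.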